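The compounds below may be only part of what the source reports. "The series", "measured", "known", "first", "only" and "open" are said of these compounds alone.

- Compound 1 `COc1ccc(-c2nc(CC(=O)c3cccc(Cl)c3)nc3ccsc23)cn1`: 30000 nM
- Compound 2 `COc1ccc(-c2nc(C(C)(C)S(=O)(=O)c3cccc(Cl)c3)nc3ccsc23)cn1`: > 50000 nM, a limit
- Compound 3 `c1ccc(-c2cc(CNc3nncc(-c4cccc5ccccc45)n3)n[nH]2)cc1`: > 10000 nM, a limit

Going by the values given here, in an ADME assay on cells (Homo sapiens) for cytotoxicity, read by resazurin assay, with a stated time of 5 days (on this read-out lower numbers stand for higher toxicity in this test and higher numbers for lower toxicity in this test), compound 1 gives 30000 nM, the only true number among the three results. The core of compound 1 is also found in compound 2. The result of compound 2 of > 50000 nM is a limit of the assay. Compound 3 is built quite differently, and its result of > 10000 nM is also a limit.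

The next compound to be tested is compound 4 `COc1ccc(-c2nc(CSc3cc(C)cc(C)c3)nc3ccsc23)cn1`, which keeps the core of compound 1 and changes only the group on the chain. The change is (3,5-dimethylphenyl)sulfanyl in place of (3-chlorophenyl)carbonyl on a saturated chain carbon bound to an aromatic carbon. Put simply, (3,5-dimethylphenyl)sulfanyl takes the place of (3-chlorophenyl)carbonyl on a saturated chain carbon bound to an aromatic carbon.

Among the compounds with values here, no pair of measured compounds shows what a swap of this kind does, so the closest guide is compound 1 at 30000 nM. In this assay the expected change is a 1.2-fold lower number from compound 1 to compound 4 (0.08 log units; within the scatter), no larger than the usual scatter and with no firm direction. For compound 4 the estimated value is 25000 nM, with an expected range from 10000 nM to 50000 nM.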

Compound 4, half-maximal cytotoxic concentration: > 50000 nM
Compound 4: no number, only a limit (the forecaster's own chance of this, stated with the estimate: 35%); middle value at least 2.0-fold (0.30 log units) from the limit.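

In this assay compound 4 gives > 50000 nM, which is a limit of the assay and not a number. Placing (3,5-dimethylphenyl)sulfanyl in place of (3-chlorophenyl)carbonyl on a saturated chain carbon bound to an aromatic carbon gives an at least 1.6-fold higher number from compound 1 to compound 4 (0.22 log units; that floor lies within the scatter), so this position accepts the swap with no sign of higher toxicity in this test, although the smallest step the result allows does not clear the usual scatter. The true size of the step stays hidden, and this limit is a common one among the compounds shown: the limit of > 50000 nM in this assay, at which 2 of the 4 values shown sit.

Compound 4 changes the linking group and the ring's substituents together, so the compounds shown cannot tell which of the two goes with the step; a (3-chlorophenyl)sulfanyl group would separate them. Also open, as far as these compounds go, is how an amine or a carboxylic acid on this same chain carbon would read in this test, and whether any group here would bring the number clearly below that of compound 1.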